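A few compounds are considered here, and "the series" means these few. Any claim that something is new, unique, unknown or untested is made for them only; others in the source may bear on it.

Compound 1 `Cc1cc(N2CC[C@@H](C)[C@@H](N(C)c3ncnc4[nH]ccc34)C2)n2nc(SCc3ccc(Cl)cc3)nc2n1` gives 18400 nM in a functional assay on HGC-27 cells (Homo sapiens) for inhibition, read by MTT assay, with a stated time of 72 h; on this read-out higher numbers stand for weaker inhibition and lower numbers for stronger inhibition. Compound 2 `Cc1ccc(CSc2nc3nc(C)cc(N4CC[C@@H](C)[C@@H](N(C)c5ncnc6[nH]ccc56)C4)n3n2)cc1` gives 15200 nM in this assay.

Of the two numbers, compound 2 holds the smaller, yet the step of a 1.2-fold lower number from compound 1 to compound 2 (0.08 log units; within the scatter) lies within the scatter, so the two compounds cannot be told apart in this assay. Compound 3 `Cc1cc(N2CC[C@@H](C)[C@@H](N(C)c3ncnc4[nH]ccc34)C2)n2nc(SCc3ccc([N+](=O)[O-])cc3)nc2n1` differs from compound 2 by nitro in place of methyl on an aromatic carbon, a change on an aromatic carbon of a six-membered aromatic ring of carbon only, para to a large group. Within the data shown here, the only measured step at that position is a 1.2-fold lower number from compound 1 to compound 2 (0.08 log units; within the scatter), and it was within the scatter; no measured step involves the nitro group, so nothing known speaks for a move beyond the scatter in either direction. Compound 3 is therefore expected to sit close to compound 2, with an estimated step of a 1.1-fold higher number from compound 2 to compound 3 (0.02 log units; within the scatter). For compound 3 the estimate in this assay is 16000 nM, within a range from 7000 nM to 36000 nM.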

Compound 3, half-maximal inhibitory concentration: 29400 nM
For compound 3 the middle estimate is 1.8-fold (0.26 log units) below the measured one; low and high end bracket the measured number.
By their numbers in this assay, from the lowest: compounds 2, 1 and 3 (each within the scatter of the next).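

In this assay nitro in place of methyl gives a 1.9-fold higher number from compound 2 to compound 3 (0.29 log units; within the scatter) and nitro in place of chloro gives a 1.6-fold higher number from compound 1 to compound 3 (0.20 log units; within the scatter), and both steps lie within the scatter. This aromatic carbon, para to a large group, has now carried a third group, one with two hydrogen-bond acceptors where methyl has none, and the three compounds still cannot be told apart in this assay. No measurement shown here offers an explanation for these numbers.

Going by these compounds, whether an amine, a carboxylic acid or a longer chain on this carbon would produce a step beyond the scatter remains open. Also open, on these data alone, is whether changes elsewhere would do so, as compounds 1, 2 and 3 all share one core and differ only at this carbon.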